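This account rests on a few compounds, and the source may have more. Where it says the series, first, only, none or still open, it means among the compounds named here.

Three compounds have been measured in a functional assay on A549 cells (Homo sapiens) for cytotoxicity; a lower number here means that less compound is needed, a higher number that more compound is needed for the effect:

compound 1, `COC(=O)C(Cc1cc(OC)c(OC)c(OC)c1)c1ccc(OC)cc1`, gives > 25 uM, which is a limit of the assay rather than a number;
compound 2, `COc1cc(/C=C\c2ccc(C(C)(C)C)cc2)cc(OC)c1OC`, gives 1.02 uM;
compound 3, `COc1cc(/C=C\c2ccc(SC)cc2)cc(OC)c1OC`, gives 1.9 uM.

Going by the values given here, compound 3 thus supplies one of only two numbers, and the nearest measured value is that of compound 2: the step of a 1.9-fold higher number from compound 2 to compound 3 (0.27 log units; within the scatter) shows that exchanging these two groups on an aromatic carbon left the read-out within the usual scatter. Compound 4, `CCCOc1ccc(/C=C\c2cc(OC)c(OC)c(OC)c2)cc1`, has not yet been measured. It differs from compound 3 in one place: propoxy in place of methylsulfanyl on an aromatic carbon. Among the compounds with values here, the only measured step that bears on this change is a 1.9-fold higher number from compound 2 to compound 3 (0.27 log units; within the scatter), which also exchanged the group on that aromatic carbon and stayed within the scatter. Given that this step stayed within the scatter, the step of a 1.2-fold higher number from compound 3 to compound 4 (0.06 log units; within the scatter) is likewise expected to remain within the scatter, leaning only slightly towards a higher number. For compound 4 the expected concentration for half-maximal effect is 2.2 uM, with a range from 0.8 uM to 6 uM.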

Compound 4, concentration for half-maximal effect: 3.9 uM
For compound 4 the middle estimate is 1.8-fold (0.25 log units) below the measured one, and the stated range covers the measured number.
By their numbers in this assay, from the lowest: compounds 2 and 3 (each within the scatter of the next); then compound 4. At a limit, above all of these: compound 1.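

In this assay the exchange of methylsulfanyl for propoxy gives a 2.1-fold higher number from compound 3 to compound 4 (0.31 log units; beyond the scatter) and so, unlike the earlier exchange on this aromatic carbon, takes the read-out beyond the scatter, if only modestly. Propoxy in place of tert-butyl gives a 3.8-fold higher number from compound 2 to compound 4 (0.58 log units; beyond the scatter) and is the larger of the two new steps, though also modest. Tert-butyl and methylsulfanyl stay within the scatter of each other, so among these three groups only propoxy stands apart, with more compound needed for the effect.

Going by these compounds, how an amine, a carboxylic acid or a chain longer than propoxy would behave on this aromatic carbon remains open. Nothing measured for these compounds gives a reason why propoxy differs from the other two groups.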